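A few compounds are considered here, and "the series" means these few. Any claim that something is new, unique, unknown or untested is made for them only; others in the source may bear on it.

In a functional assay on DLD-1 cells (Homo sapiens) for inhibition, with a stated time of 48 h (on this read-out higher numbers stand for weaker inhibition and lower numbers for stronger inhibition), compound 1 (`COc1ccc2c(=O)cc(/C=C/[S+](C)[O-])oc2c1O`) gives > 10000 nM as a limit of the assay. Compound 2 (`COc1cc2oc(/C=C/[S+](C)[O-])cc(=O)c2cc1O`) gives > 10000 nM as a limit too. It therefore stands with compound 1 (the limit of > 10000 nM in this assay, at which 2 of the 2 values shown sit). Compound 3 (`COc1cc2oc(/C=C/[S+](C)[O-])cc(=O)c2cc1OC`) differs from compound 2 by methyl in place of hydrogen on an oxygen on an aromatic ring in the form of methyl in place of hydrogen on an oxygen on an aromatic ring, hydroxy to methoxy. Among the compounds with values here, no measured pair shows this change, and no step beyond the scatter is expected in this assay in either direction. The expected step (a step that the limit leaves unreadable from compound 2 to compound 3) is correspondingly small. Compound 3 is estimated at 12000 nM with a range of 4000 nM to 40000 nM, and a limit of the assay is again expected.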

Compound 3, half-maximal inhibitory concentration: 4200 nM
For compound 3 the middle estimate is 2.9-fold (0.46 log units) above the measured one; measured number inside the range.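

In this assay, methyl in place of hydrogen on an oxygen on an aromatic ring, hydroxy to methoxy, gives an at least 2.3-fold lower number from compound 2 to compound 3 (0.37 log units; beyond the scatter). This is the only readable step among the compounds shown, and compound 3 is the only one with a number rather than a limit. The full size of the step stays unknown because compound 2 sits at a limit: the limit of > 10000 nM in this assay, at which 2 of the 3 values shown sit.

The compounds shown leave open whether an ethoxy group on the same oxygen, or an amine in place of the hydroxy, would move the number further. They also leave open whether the same change on the hydroxy of compound 1 would give a step.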